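Swapping fluoro for methoxy on the benzyl group

The source may hold more compounds than are shown below. What is called first, only, known or untested is meant among the compounds shown, and "the series" means these compounds.

Compound 1, `CCN1CCN(CCCn2cnc3c(N4CCN(CC)CC4)ncnc32)CC1`, in a physicochemical assay for solubility, with a stated time of 18 h, at pH 7.4 (on this read-out lower numbers stand for lower solubility and higher numbers for higher solubility), compound 1 gives 200 ug/mL.
Compound 2, `CCN1CCN(c2nc(NCc3ccc(F)cc3)nc3c2ncn3CCCN2CCCC2)CC1`, in this assay compound 2 gives 218 ug/mL.
Compound 3, `Fc1ccc(CNc2nc(N3CCN(C4CCCC4)CC3)c3ncn(CCCN4CCCC4)c3n2)cc1`, in this assay compound 3 gives 28 ug/mL.

Among the three measured compounds, compound 2 carries the highest number in this assay, though compound 1 sits so close that the two cannot be told apart by this measurement. Among the compounds with values here, compound 3 lies clearly lower: the step of a 7.8-fold lower number from compound 2 to compound 3 (0.89 log units; beyond the scatter) is the one change in the set that moved the read-out beyond the scatter, and it exchanged cyclopentyl for ethyl on an amine nitrogen in a ring.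

Compound 4, `CCN1CCN(c2nc(NCc3ccc(OC)cc3)nc3c2ncn3CCCN2CCCC2)CC1`, has not yet been measured. It departs from compound 2 at a different spot: methoxy in place of fluoro on an aromatic carbon. Within the data shown here, none of the measured steps touches this part of the molecule, so nothing among the three compounds speaks directly to the change. Among the measured compounds shown here, the small size of the swap, a single fluorine leaving and a methoxy with one hydrogen-bond acceptor entering, gives no reason to expect a shift as large as the one seen between compound 2 and compound 3. Compound 4 is therefore expected to stay near compound 2, with the step of a 1.1-fold lower number from compound 2 to compound 4 (0.06 log units; within the scatter) estimated to fall within the scatter. The estimate for compound 4 in this assay is 190 ug/mL, ranging from 90 ug/mL to 350 ug/mL.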

Compound 4, solubility: 49.4 ug/mL
Compound 4: middle estimate off by 3.8-fold (0.59 log units), on the high side; measured number below the stated range.
By their numbers in this assay, from the lowest: compounds 3 and 4 (each within the scatter of the next); then compounds 1 and 2 (each within the scatter of the next).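

In this assay, exchanging 4-fluorobenzyl for 4-methoxybenzyl gives a 4.4-fold lower number from compound 2 to compound 4 (0.64 log units; beyond the scatter), so the aromatic carbon carrying this group is a place where a small edit can move the number beyond the scatter. Within the data shown here, until now, the only step to do so was the one on the amine nitrogen in a ring, a 7.8-fold lower number from compound 2 to compound 3 (0.89 log units; beyond the scatter), and this result adds a second, separate part of the molecule where a single change is followed by a lower number, even though only one fluorine leaves and only a methoxy of two heavy atoms enters. No measurement at hand bears on why the number falls with this swap, so the result stands as an observation without an explanation.

From the compounds shown here alone, it remains open whether the lower number is tied to methoxy itself or would also follow other replacements of fluoro at the same place, such as a methyl, a chlorine, a hydroxyl or a plain hydrogen. Going by these compounds, it is equally open whether the same swap would give a step of similar size with cyclopentyl in place of ethyl on the amine nitrogen in a ring.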